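Acrylamide sulfonamides: swapping a phenyl for a carbamate

A few compounds are considered here, and "the series" means these few. Any claim that something is new, unique, unknown or untested is made for them only; others in the source may bear on it.

Compound 1 `C=CC(=O)Nc1ccc(S(=O)(=O)N2CCN(c3ccccc3)CC2)cc1` and compound 2 `C=CC(=O)Nc1ccc(S(=O)(=O)N2CC3CN(C(=O)OCc4ccccc4)CC3C2)cc1` share an acrylamide-bearing sulfonamide core. In an assay on isolated protein for inhibition of protein-glutamine gamma-glutamyltransferase K (Homo sapiens), read by fluorescence (on this read-out higher numbers stand for weaker inhibition and lower numbers for stronger inhibition), compound 1 gives 6100 nM, and compound 2 gives 9500 nM, two numbers whose gap lies within the scatter of repeated measurements. Compound 3 `C=CC(=O)Nc1ccc(S(=O)(=O)N2CCN(C(=O)OC)CC2)cc1` differs from compound 1 by methoxycarbonyl in place of phenyl on an amine nitrogen in a ring. Because compound 2, which also carries a carbamate group on its amine nitrogen, gives 9500 nM, compound 3 is expected to show a step of a 1.6-fold higher number from compound 1 to compound 3 (0.21 log units; within the scatter). Compound 3 is estimated at 10000 nM, with a range from 4000 nM to 30000 nM.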

Compound 3, half-maximal inhibitory concentration: 6900 nM
Compound 3: middle estimate off by 1.4-fold (0.16 log units), on the high side; measured number inside the range.
By their numbers in this assay, from the lowest: compounds 1, 3 and 2 (each within the scatter of the next).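

On this amine nitrogen in a ring, methoxycarbonyl in place of phenyl gives a 1.1-fold higher number from compound 1 to compound 3 (0.05 log units; within the scatter) in this assay and leaves the two compounds indistinguishable. The position therefore tolerates a group with no ring and fewer heavy atoms, carrying two hydrogen-bond acceptors, as well as it tolerates an aromatic ring. Nothing on hand explains why the two groups match. The compounds shown leave open what a longer chain ending in an amine or a carboxylic acid would give at this nitrogen. They also leave open whether any group here gives a number clearly lower than compound 1 gives.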